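Shifting the methyl along the carboxyalkyl chain

The source may hold more compounds than are shown below. What is called first, only, known or untested is meant among the compounds shown, and "the series" means these compounds.

Two compounds share a core built around a quinoline-type ether linkage. Compound 1 `c1ccc2nc(COc3ccc(OCCCc4nnn[nH]4)cc3)ccc2c1` gives 250 nM in a functional assay (lung) for inhibition, with Cavia porcellus as the target; on this read-out lower numbers stand for stronger inhibition and higher numbers for weaker inhibition. Compound 2 `CC(CCCC(=O)O)c1cccc(OCc2ccc3ccccc3n2)c1` gives 500 nM in this assay, a number that lies within the usual scatter of the value of compound 1, so the two cannot be told apart. Compound 3 `CC(Cc1cccc(OCc2ccc3ccccc3n2)c1)CC(C)C(=O)O` carries the change (4-carboxy-2-methylpentyl in place of 4-carboxy-1-methylbutyl on an aromatic carbon). Nothing measured here shows what such a chain alteration does, so the step is expected to be small, with no direction beyond the scatter, which is what no change at the digits printed from compound 2 to compound 3 (within the scatter) expresses. Compound 3 is therefore estimated at 500 nM, with a range from 150 nM to 1600 nM.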

Compound 3, half-maximal inhibitory concentration: 500 nM
Beside the measured number, compound 3's estimate shows no gap at the digits printed; the range from low to high includes it.
By their numbers in this assay, from the lowest: compounds 1, 2 and 3 (each within the scatter of the next).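

Moving the methyl along the chain gives no change at the digits printed from compound 2 to compound 3 (within the scatter) in this assay as the first comparison here that differs in only one place. At this aromatic carbon, 4-carboxy-2-methylpentyl and 4-carboxy-1-methylbutyl cannot be told apart, even though the entering chain is one carbon larger. Nothing available explains this result. The compounds shown leave open how this position would respond to a chain with no methyl at all. They also leave open whether an amide could replace the carboxylic acid at the chain end.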